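The source may hold more compounds than are shown below. What is called first, only, known or untested is meant among the compounds shown, and "the series" means these compounds.

Of the compounds shown here, three have so far been measured in a functional assay on the whole organism (B cells) with Mus musculus as the target; on this read-out higher numbers stand for larger maximal responses and lower numbers for smaller maximal responses. Compound 1 `Nc1nc(O)c2c(n1)n(C1OC(CO)[C@@H](O)[C@H]1O)c(=O)n2Cc1ccc(Cl)cc1` gives 15% in this assay, the lowest of the three numbers. Compound 2 `C=CCn1c(=S)n(C2OC(COCc3ccccc3)[C@H]3OC(C)(C)O[C@@H]23)c2nc(N)nc(O)c21` reaches 77% in this assay, and compound 3 `C=CCSc1nc2c(O)nc(N)nc2n1C1OC(CO)[C@@H](O)[C@H]1O` reaches 107%. Both gaps to compound 1 lie beyond the scatter of repeated measurements, so compound 1 stands clearly apart at the bottom. No two of these compounds differ in only one place, so no single structural step has yet been measured.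

Compound 4 `CCCCn1c(=O)n(C2OC(CO)[C@@H](O)[C@H]2O)c2nc(N)nc(O)c21` has not been measured. It differs from compound 1 in one place: propyl in place of 4-chlorophenyl on a saturated chain carbon bound to an aromatic nitrogen. Everything else in the molecule is unchanged. Among the measured compounds shown here, no measured pair isolates a change of this kind, so nothing shows which way it moves the response. Compound 4 is expected to give 35% in this assay, with a range from 10% to 80%. The expected step is a number 20 percentage points higher from compound 1 to compound 4 (beyond the scatter), upward, though it may not clear the scatter.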

Compound 4, largest response reached (reported as maximal response), in percent of the reference or control that the assay uses: 86%
Compound 4: the middle estimate sits 51 percentage points below what was measured; measured number outside the range, above it.
By their numbers in this assay, from the lowest: compound 1; then compounds 2 and 4 (each within the scatter of the next); then compound 3.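

In this assay, among the compounds shown here, the change of propyl in place of 4-chlorophenyl on a saturated chain carbon bound to an aromatic nitrogen gives a number 71 percentage points higher from compound 1 to compound 4 (beyond the scatter) and is the first single change that can be read. The group at this position can therefore, on its own, separate a small maximal response from a much larger one, with the rest of the molecule unchanged. No measurement shown explains why the response rises with this change.

This single pair swaps the ring and its chlorine together, so it cannot tell whether losing the chlorine, losing the ring or gaining the open chain matters most. A plain benzyl group would separate the chlorine from the ring, while a hexyl chain would show whether the response holds as the chain grows longer.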